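Working notes on compounds 1 to 3, cell cytotoxicity

This account rests on a few compounds, and the source may have more. Where it says the series, first, only, none or still open, it means among the compounds named here.

Measured so far:
compound 1 `COc1cc2c(Oc3ccc(NC(=O)N/N=C/c4ccc(C(F)(F)F)cc4)cc3F)ccnc2cc1OCCCN1CCCC1` — 790 nM
compound 2 `COc1cc2c(Oc3ccc(NC(=O)N/N=C/c4ccc(OC(F)(F)F)cc4)cc3F)ccnc2cc1OCCCN1CCCCC1` — 590 nM

In a functional assay on A549 cells (Homo sapiens) for cytotoxicity, read by MTT assay, with a stated time of 72 h (a higher number here means a weaker inhibitor, a lower number a stronger inhibitor), compound 2 gives 590 nM and compound 1 gives 790 nM. Compound 2 has the lowest of the two numbers, but its nearest neighbour, compound 1, lies within the scatter of it, so no order between the two can be read from these values.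

The next compound, compound 3 `C=CCc1cccc(/C=N/NC(=O)Nc2ccc(Oc3ccnc4cc(OCCCN5CCCCC5)c(OC)cc34)c(F)c2)c1OC`, differs from compound 2 at one place: 3-allyl-2-methoxyphenyl in place of 4-(trifluoromethoxy)phenyl on a carbon with a double bond to nitrogen. Among the measured compounds shown here, no step between measured compounds covers this kind of change, so there is nothing in the two values from which its size or direction could be taken. The shared core is untouched in all three compounds, and both measured values sit close together, so the expectation for compound 3 is a step in this assay of no more than the usual scatter, with the direction left open and the range kept wide. For compound 3 the expected step from compound 2 is a 1.4-fold higher number from compound 2 to compound 3 (0.13 log units; within the scatter). The estimated value for compound 3 in this assay is 800 nM, within 250 nM to 2500 nM.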

Compound 3, half-maximal inhibitory concentration: 250 nM
Estimate against measurement, compound 3: 3.2-fold (0.51 log units) above; the range from low to high includes it.
By their numbers in this assay, from the lowest: compound 3; then compounds 2 and 1 (each within the scatter of the next).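

The position on the carbon with a double bond to nitrogen is shown here for the first time to respond to a change of group: in this assay, 3-allyl-2-methoxyphenyl in place of 4-(trifluoromethoxy)phenyl gives a 2.4-fold lower number from compound 2 to compound 3 (0.37 log units; beyond the scatter), a modest step that lies beyond the scatter. The two groups match in heavy atoms, in their single six-membered aromatic ring of carbon only, and in hydrogen-bond donors and acceptors, so the step appears without any change in those counts, while the fluorine atoms leave and a double bond outside aromatic rings enters. No measurement shown here bears on what lies behind this step.

With both the allyl and the methoxy group entering together, the compounds shown leave open whether either alone, as in 3-allylphenyl or 2-methoxyphenyl, would carry the step. Also open, from the compounds shown here alone, is how this position would respond to a group of another kind on the same ring, such as an amine or a carboxylic acid, and whether the step would hold with the pyrrolidine ring of compound 1 at the far end of the chain.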